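From 2,4-dimethylphenyl to 3-methoxyphenyl on the sulfonamide nitrogen

The source may hold more compounds than are shown below. What is called first, only, known or untested is meant among the compounds shown, and "the series" means these compounds.

In a functional assay on HT-29 cells (Homo sapiens) for antiproliferative activity, read by sulforhodamine B assay, with a stated time of 48 h (on this read-out higher numbers stand for weaker inhibition and lower numbers for stronger inhibition), compound 1 (`COc1ccc(NS(=O)(=O)c2ccc(N3CCNC3=O)cc2)cc1OC`) gives 520 nM, while compound 2 (`Cc1ccc(NS(=O)(=O)c2ccc(N3CCNC3=O)cc2)c(C)c1`) gives 180 nM. Compound 2 therefore holds the lower of the two numbers, with a gap beyond the usual scatter. Compound 3 (`COc1cccc(NS(=O)(=O)c2ccc(N3CCNC3=O)cc2)c1`) carries 3-methoxyphenyl in place of 2,4-dimethylphenyl on a sulfonamide nitrogen. Going by the values given here, the only measured compound with methoxy groups, compound 1 at 520 nM, has the higher number, which points to weaker inhibition. The expected step is a 2.8-fold higher number from compound 2 to compound 3 (0.44 log units; beyond the scatter), in the direction of weaker inhibition in this assay and beyond the scatter. For compound 3 the estimated value is 500 nM, with an expected range of 180 nM to 1400 nM.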

Compound 3, half-maximal inhibitory concentration: 120 nM
For compound 3 the middle estimate is 4.2-fold (0.62 log units) above the measured one; measured number outside the range, below it.
By their numbers in this assay, from the lowest: compounds 3 and 2 (each within the scatter of the next); then compound 1.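

In this assay 3-methoxyphenyl in place of 2,4-dimethylphenyl on a sulfonamide nitrogen gives a 1.5-fold lower number from compound 2 to compound 3 (0.18 log units; within the scatter) and so leaves the two groups indistinguishable at this position. Methoxy on this ring therefore does not by itself go with weaker inhibition, while hydrogen in place of methoxy on an aromatic carbon gives a 4.3-fold lower number from compound 1 to compound 3 (0.64 log units; beyond the scatter) and ties the gap to the additional methoxy of compound 1. Nothing available explains either step.

From the compounds shown here alone, whether an amine or a carboxylic acid on this ring would fit as well remains open. So does the effect of a longer chain such as ethoxy in place of methoxy.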